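The compounds below may be only part of what the source reports. "The series", "measured", "known", "first", "only" and "open" are said of these compounds alone.

Compound 1, `CCC(C(=O)N1CCN(c2cccc(F)c2)CC1)N1C(=O)CCC1=O`, is a succinimide-bearing amide joined to a piperazine that carries a 3-fluorophenyl group. In a functional assay on the whole organism (strain Swiss) with Mus musculus as the target, in the maximal electroshock model, with a stated time of 1 h, at a dose of 300 mg/kg by the intraperitoneal route (on this read-out higher numbers stand for a stronger effect at the one dose given and lower numbers for a weaker effect), compound 1 gives 75%. Compound 2, `CCC(C(=O)N1CCN(c2cccc(C(F)(F)F)c2)CC1)N1C(=O)CCC1=O`, differs from it only on the aromatic ring, and in this assay compound 2 gives 100%. Going by the values given here, of the two numbers measured so far, compound 1 stands lowest, with a number 25 percentage points higher from compound 1 to compound 2 (beyond the scatter) separating it from compound 2.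

Compound 3, `CCC(C(=O)N1CCN(c2ccc(Cl)cc2)CC1)N1C(=O)CCC1=O`, has not yet been measured. It differs from compound 1 in one place: 4-chlorophenyl in place of 3-fluorophenyl on an amine nitrogen in a ring. Among the compounds with values here, no measured step shows exactly this swap; the only step available, a number 25 percentage points higher from compound 1 to compound 2 (beyond the scatter), shows that changing the group on this aromatic ring raised the read-out, though that step exchanged fluoro for trifluoromethyl rather than one halogen for another. A small rise or no change beyond the scatter is therefore the most reasonable expectation. For compound 3 in this assay the expected value is 85%, within a range of 65% to 100%, which would mean an expected step of a number 10 percentage points higher from compound 1 to compound 3 (within the scatter).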

Compound 3, a percentage reported as activity, at one dose (the size of the read-out at that dose, not a potency): 25%
The estimate for compound 3 lay 60 percentage points above the measured number; measured number outside the range, below it.
By their numbers in this assay, from the lowest: compound 3; then compound 1; then compound 2.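

The earlier step showed only a rise, whereas this one shows that the aryl group on the ring nitrogen can also cost much of the effect in this assay: there is a number 50 percentage points lower from compound 1 to compound 3 (beyond the scatter), a large change beyond the scatter from a swap that looks minor on paper. The leaving 3-fluorophenyl and the entering 4-chlorophenyl have the same heavy-atom count, and neither has a hydrogen-bond donor or acceptor, so these simple counts do not separate the two groups even though their read-outs differ widely. No measurement available here bears on why the read-out dropped.

This swap changes two things at once, the halogen and its place on the aromatic ring, so the compounds shown leave open which of the two goes with the drop. A 3-chlorophenyl or a 4-fluorophenyl group on the same ring nitrogen would pull these two changes apart, since each differs from compound 1 in only one of them.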